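Thiophen-2-yl replaces 4-fluorophenyl on a triple-bonded carbon

This account rests on a few compounds, and the source may have more. Where it says the series, first, only, none or still open, it means among the compounds named here.

In a functional assay on HL-60 cells (Homo sapiens) for antiproliferative activity, with a stated time of 72 h (a higher number here means a weaker inhibitor, a lower number a stronger inhibitor), compound 1 (`Nc1ncnn2c([C@@H]3O[C@H](CO)[C@@H](O)[C@H]3O)cc(C#CC3CC3)c12`) gives 40 nM as its value. Compound 2 (`Nc1ncnn2c([C@@H]3O[C@H](CO)[C@@H](O)[C@H]3O)cc(C#Cc3ccc(F)cc3)c12`) gives > 100000 nM, which is a limit of the assay and not a number. Compound 3 (`Nc1ncnn2c([C@@H]3O[C@H](CO)[C@@H](O)[C@H]3O)cc(C#Cc3cccs3)c12`) differs from compound 2 by thiophen-2-yl in place of 4-fluorophenyl on a triple-bonded carbon, with thiophen-2-yl in place of 4-fluorophenyl on a triple-bonded carbon. Among the compounds with values here, the only measured step at that carbon is large, an at least 2500-fold higher number from compound 1 to compound 2 (3.39 log units; beyond the scatter), and it brought in an aromatic ring, as this change keeps one. Only a modest shift toward stronger inhibition is therefore expected in this assay, namely an at least 3.3-fold lower number from compound 2 to compound 3 (0.52 log units; beyond the scatter). Compound 3 is estimated at 30000 nM, within 3000 nM to 100000 nM.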

Compound 3, half-maximal inhibitory concentration: > 100000 nM
Compound 3 was reported as a limit; the forecaster's own chance of this, stated with the estimate: 60%; at least 3.3-fold (0.52 log units) between middle value and limit.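

In this assay, thiophen-2-yl in place of cyclopropyl on the triple-bonded carbon gives an at least 2500-fold higher number from compound 1 to compound 3 (3.39 log units; beyond the scatter) and so matches the loss seen with 4-fluorophenyl, showing that this loss is not confined to a six-membered aromatic ring. The value of compound 3 is a limit of the assay and not a number. The step between compound 2 and compound 3 cannot be read because both sit at that limit: the limit of > 100000 nM in this assay, at which 2 of the 3 values shown sit. From the compounds shown here alone, it remains open whether a propyl chain, a cyclohexyl ring or a chain ending in an amine on this carbon would stay near compound 1.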